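This account rests on a few compounds, and the source may have more. Where it says the series, first, only, none or still open, it means among the compounds named here.

Compound 1 `CC(/C=N/Nc1nc(N)c2ncn([C@@H]3O[C@H](CO)[C@@H](O)[C@H]3O)c2n1)Cc1ccc(C(C)C)cc1` in an assay on CHO-K1 cells for displacement of a labelled ligand from adenosine receptor A1 (Homo sapiens), read by scintillation counting, with a stated time of 60 min (on this read-out higher numbers stand for weaker inhibition and lower numbers for stronger inhibition), gives 9500 nM. Compound 2 `Nc1nc(N/N=C/c2ccc[nH]2)nc2c1ncn2[C@@H]1O[C@H](CO)[C@@H](O)[C@H]1O` in this assay gives 8 nM. Compound 3 `Nc1nc(N/N=C/c2ccc(-c3ccccc3)cc2)nc2c1ncn2[C@@H]1O[C@H](CO)[C@@H](O)[C@H]1O` in this assay gives 7860 nM.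

Among these three, compound 2 has the lowest number and so the strongest inhibition; compound 3 and compound 1 both sit far above it, well beyond the scatter. Compound 4 `Nc1nc(N/N=C/C2CCCC2)nc2c1ncn2[C@@H]1O[C@H](CO)[C@@H](O)[C@H]1O` is not yet measured in this assay. Among the measured compounds shown here, it differs from compound 2 in one place: cyclopentyl in place of 1H-pyrrol-2-yl on a carbon with a double bond to nitrogen No step between measured compounds traces this exact change, so its size is uncertain. The measured values show that the group on the carbon with a double bond to nitrogen moves the numbers widely, with compound 2 lowest. A step upward in this assay, toward weaker inhibition, is expected, though smaller than the gaps to compound 1 or compound 3. Compound 4 is estimated at 300 nM, ranging from 30 nM to 3000 nM, an expected step of a 38-fold higher number from compound 2 to compound 4 (1.57 log units; beyond the scatter).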

Compound 4, inhibition constant: 5.6 nM
Compound 4: the middle estimate sits 54-fold (1.73 log units) above what was measured; measured number outside the range, below it.
By their numbers in this assay, from the lowest: compounds 4 and 2 (each within the scatter of the next); then compounds 3 and 1 (each within the scatter of the next).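

In this assay, cyclopentyl in place of 1H-pyrrol-2-yl gives a 1.4-fold lower number from compound 2 to compound 4 (0.15 log units; within the scatter) and this step lies within the scatter. On this carbon with a double bond to nitrogen, then, neither an aromatic ring nor the pyrrole's hydrogen-bond donor is needed for a low number, at least with these two five-membered rings. No measurement given here explains why the two groups read alike.

Still open, as far as these compounds go, is whether a cyclohexyl ring, a plain phenyl ring or a short chain such as isopropyl would also keep the number this low.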